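The source may hold more compounds than are shown below. What is called first, only, known or untested is meant among the compounds shown, and "the series" means these compounds.

In an assay on HEK293 cells for negative allosteric modulation of metabotropic glutamate receptor 5 (Homo sapiens), read by FLIPR, with a stated time of 1 h (a lower number here means a stronger inhibitor, a higher number a weaker inhibitor), compound 3 `CCC(=O)N1CCc2nc(C#Cc3ccccc3)sc2C1` gives 38 nM, the lowest of the two numbers shown. Its nearest neighbour, compound 2 `Fc1cccc(C#Cc2nc3c(s2)CN(C2CCC2)CC3)c1`, gives 200 nM in this assay. Compound 1 `CN1CCc2nc(C#Cc3cccc(F)c3)sc2C1` reaches only a limit of this assay, > 10000 nM, a limit at which (the limit of > 10000 nM in this assay, at which 1 of the 3 values shown sits). Compound 4 `O=C(C1CCCCC1)N1CCc2nc(C#Cc3ccccc3)sc2C1` differs from compound 3 by cyclohexyl in place of ethyl on a carbonyl carbon. Among the compounds with values here, the one measured step, an at least 50-fold lower number from compound 1 to compound 2 (1.69 log units; beyond the scatter), is of a kindred sort, a ring replacing a short chain, yet on an amine nitrogen in a ring rather than on a carbonyl carbon, so it bears on the new step only loosely. The author therefore expects at most a modest step in this assay, if any beyond the scatter, and estimates for compound 4 a value of 25 nM, between 8 nM and 80 nM, which is an expected step of a 1.5-fold lower number from compound 3 to compound 4 (0.18 log units; within the scatter).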

Compound 4, half-maximal inhibitory concentration: > 10000 nM
Compound 4 gave a limit, no number (the forecaster's own chance of this, stated with the estimate: 3%); middle value at least 400-fold (2.60 log units) away from the limit.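

On a carbonyl carbon whose other neighbour is an amide-type nitrogen in a ring, this position does not tolerate every larger group: in this assay, cyclohexyl in place of ethyl gives an at least 260-fold higher number from compound 3 to compound 4 (2.42 log units; beyond the scatter). A ring on an amine nitrogen in a ring went with a lower number in an at least 50-fold lower number from compound 1 to compound 2 (1.69 log units; beyond the scatter), and that direction does not carry over to this place. Compound 4 gives a limit, not a number: the limit of > 10000 nM in this assay, at which 2 of the 4 values shown sit.

The compounds shown leave open where between ethyl and cyclohexyl the loss sets in. A cyclopropyl, a cyclobutyl or a longer open chain on the same carbonyl carbon would separate the effect of the ring from that of its size.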